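The compounds below may be only part of what the source reports. "The series", "measured", "known", "first", "only" and "open" are said of these compounds alone.

Of the compounds shown here, three have so far been tested in a functional assay on LoVo cells (Homo sapiens) for cytotoxicity, read by colorimetric assay and MTT assay; on this read-out higher numbers stand for weaker inhibition and lower numbers for stronger inhibition. Compound 1 `COc1cccc2cc(-c3ccccc3)c(O)nc12` gives 10000 nM, and compound 2 `COc1ccc2cc(-c3ccccc3)c(O)nc2c1` gives 10000 nM. Compound 3 `CCOC(=O)Cn1c(=O)c(-c2ccc(OC)cc2)cc2c(OC)cc(OC)cc21`, which carries an ethoxycarbonyl group, gives 10000 nM, so it stands level with compound 1 and compound 2 on these numbers.

Compound 4 `COc1ccc(-c2cc3c(OC)cc(OC)cc3n(CC(=O)OCc3ccccc3)c2=O)cc1` is the same as compound 3 except for one change: phenyl in place of methyl on a saturated chain carbon bound to an oxygen next to a carbonyl group. Phenyl takes the place of methyl on a saturated chain carbon bound to an oxygen next to a carbonyl group, which turns ethoxycarbonyl into benzyloxycarbonyl.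

Within the data shown here, no two measured compounds differ in just one place, so the data give no direct guide to the effect of this change. The three measured values also show no spread to build on. In this assay the expected result is a 1.1-fold lower number from compound 3 to compound 4 (0.05 log units; within the scatter), which is no step beyond the usual scatter. For compound 4 the estimated value is 9000 nM, with an expected range from 3000 nM to 15000 nM.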

Compound 4, half-maximal inhibitory concentration: 10000 nM
Estimate against measurement, compound 4: 1.1-fold (0.05 log units) below; measured number inside the range.
By their numbers in this assay, from the lowest: compounds 1, 2, 3 and 4 (each within the scatter of the next).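

In this assay, among these compounds, phenyl in place of methyl on a saturated chain carbon bound to an oxygen next to a carbonyl group gives no change at the digits printed from compound 3 to compound 4 (within the scatter), and this is the first step that can be read between two compounds differing in one place. It shows that, at this position, turning ethoxycarbonyl into benzyloxycarbonyl adds a six-membered aromatic ring without taking the number beyond the usual scatter. Nothing measured here offers an explanation for this result.

Still open, as far as these compounds go, is whether a carboxylic acid in place of the ethoxycarbonyl, or an amine on a longer chain, would move the number beyond the scatter. Also open, from the compounds shown here alone, is whether a benzyl group carrying a further group, such as a methoxy, would behave as the plain benzyl does.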